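A few compounds are considered here, and "the series" means these few. Any claim that something is new, unique, unknown or untested is made for them only; others in the source may bear on it.

Measured so far:
- compound 1 `O=C(CCCCCNc1c(Nc2ccccc2)c(=O)c1=O)NO`; in an ADME assay on cells (Hepatocyte, Homo sapiens) for pharmacokinetics, read by LC-MS, with a stated time of 90 min, tested at 1 uM (a lower number here means slower removal, a higher number faster removal of the compound), compound 1 gives < 4.8 uL/min, which is a limit of the assay.
- compound 2 `O=C(CCCCCNc1c(NC2CCCCC2)c(=O)c1=O)NO`; in this assay compound 2 gives < 5 uL/min, also a limit of the assay.

Among the measured compounds shown here, compound 2 stands only at a limit in this assay, with no number of its own, and the one other value shown for the series is likewise a limit, as the limit of < 4.8 uL/min in this assay, at which 1 of the 2 values shown sits, and the limit of < 5 uL/min in this assay, at which 1 of the 2 values shown sits, record. For the measured compounds named here, the single measured step, a step that the two limits leave unreadable from compound 1 to compound 2, is therefore not readable in size or direction.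

The next compound, compound 3 `Cc1ccccc1Nc1c(NCCCCCC(=O)NO)c(=O)c1=O`, differs from compound 2 as follows: 2-methylphenyl in place of cyclohexyl on a nitrogen on an aromatic ring. Going by the values given here, no measured step has a readable size that bears on this change. Both measured compounds sit at the limit, so compound 3 is expected to stay near it, with a step that the limit leaves unreadable from compound 2 to compound 3 expected to be no step beyond the scatter. For compound 3 the estimate in this assay is 3.5 uL/min, expected to lie between 1.5 uL/min and 9 uL/min.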

Compound 3, intrinsic clearance in a liver preparation (reported as CLH), per the amount of preparation that the assay uses: < 5 uL/min
Compound 3: no number, only a limit (the forecaster's own chance of this, stated with the estimate: 65%); the middle value does not contradict the limit.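

Compound 3 gives only a limit in this assay, like compound 1 and compound 2, so no step among these three compounds can be read in size or direction. The compounds shown leave open what number each would carry and whether the group on this nitrogen changes it.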